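Ring swap on the aryl-methoxy arm of the shared core

The source may hold more compounds than are shown below. What is called first, only, known or untested is meant among the compounds shown, and "the series" means these compounds.

Compound 1 `Cn1c(C2CC2)nc2ccc(-n3ccc(OCc4ccc(Cl)cc4)cc3=O)cc21` carries a 4-chlorophenyl on the saturated chain carbon bound to an oxygen on an aromatic ring; in an assay on CHO cells for displacement of a labelled ligand from melanin-concentrating hormone receptor 1 (Homo sapiens), read by scintillation counting, with a stated time of 1 h (on this read-out lower numbers stand for stronger inhibition and higher numbers for weaker inhibition), compound 1 gives 35 nM. Compound 2 `Cn1c(C2CC2)nc2ccc(-n3ccc(OCc4ncc(Cl)cn4)cc3=O)cc21` holds a 5-chloropyrimidin-2-yl in that place. In this assay compound 2 reaches only > 1000 nM, which is a limit and not a number (the limit of > 1000 nM in this assay, at which 1 of the 2 values shown sits). Within the data shown here, the one measured step, an at least 28-fold higher number from compound 1 to compound 2 (1.45 log units; beyond the scatter), shows the six-membered ring with two hetero atoms to be far weaker than the chlorophenyl. Compound 3 `Cn1c(C2CC2)nc2ccc(-n3ccc(OCc4ccc(Cl)s4)cc3=O)cc21` makes the change 5-chlorothiophen-2-yl in place of 5-chloropyrimidin-2-yl on a saturated chain carbon bound to an oxygen on an aromatic ring: a five-membered ring with one hetero atom enters, closer in kind to the chlorophenyl of compound 1 than to the pyrimidine of compound 2. Compound 2 stands at a limit, so the step from it is bounded from one side only. For compound 3 a large fall in this assay is expected, an at least 16-fold lower number from compound 2 to compound 3 (1.22 log units; beyond the scatter). Compound 3 is estimated at 60 nM, within 20 nM to 250 nM.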

Compound 3, half-maximal inhibitory concentration: 19 nM
Compound 3: the middle estimate sits 3.2-fold (0.50 log units) above what was measured; the whole stated range lies above it.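

On this position the phenyl ring is not the only ring that holds up: 5-chlorothiophen-2-yl in place of 5-chloropyrimidin-2-yl gives an at least 52-fold lower number from compound 2 to compound 3 (1.72 log units; beyond the scatter) in this assay. The size of that step is open on one side, as compound 2 stands at a limit and not at a number: the limit of > 1000 nM in this assay, at which 1 of the 3 values shown sits. Against the 4-chlorophenyl, the same ring gives a 1.8-fold lower number from compound 1 to compound 3 (0.27 log units; within the scatter), so among these compounds a five-membered aromatic ring with 1 hetero atom serves as well as the six-membered carbon ring, and a hetero atom in the ring does not by itself go with the loss seen for compound 2.

Going by these compounds, whether a single ring nitrogen, as in a chloropyridine, already goes with that loss stays open. On these data alone, all three compounds carry chlorine, so it is also open whether a methyl or a nitrile could stand in its place on the thiophene.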